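A Carboxy Swap at the Limit of Stability

The compounds below may be only part of what the source reports. "The series", "measured", "known", "first", "only" and "open" are said of these compounds alone.

Measured in a physicochemical assay, read by HPLC, in phosphate buffer, with a stated time of 24 h, at pH 7.4 (on this read-out higher numbers stand for a more stable compound and lower numbers for a less stable compound), so far:
Compound 1 `CCCCCc1ccc(-c2cc3cn([C@H]4C[C@H](O)[C@@H](COC(=O)[C@H](CC(C)C)NC(=O)[C@@H]5CCCN5C(=O)[C@@H](N)C(C)C)O4)c(=O)nc3o2)cc1` gives 69% as a number
Compound 2 `CCCCCc1ccc(-c2cc3cn([C@H]4C[C@H](O)[C@@H](COC(=O)[C@@H](NC(=O)[C@@H]5CCCN5C(=O)[C@@H](N)CC(N)=O)C(C)C)O4)c(=O)nc3o2)cc1` gives > 95% as a limit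
Compound 3 `CCCCCc1ccc(-c2cc3cn([C@H]4C[C@H](O)[C@@H](COC(=O)[C@@H](NC(=O)[C@@H]5CCCN5C(=O)[C@@H](N)CCCCN)C(C)C)O4)c(=O)nc3o2)cc1` gives > 95% as a limit

The position of compound 3 is known only through the limit of > 95% in this assay, at which 2 of the 3 values shown sit, and no number can be read for it. For the measured compounds named here, compound 1 differs from the other two in more than one place, so its value of 69% gives no single step to follow here.

The next compound is compound 4 `CCCCCc1ccc(-c2cc3cn([C@H]4C[C@H](O)[C@@H](COC(=O)[C@@H](NC(=O)[C@@H]5CCCN5C(=O)[C@@H](N)CC(=O)O)C(C)C)O4)c(=O)nc3o2)cc1` and the change is carboxy in place of 3-aminopropyl on a saturated chain carbon, two bonds along the chain from an amine nitrogen and a carbonyl carbon which in words is carboxy in place of 3-aminopropyl on a saturated chain carbon, two bonds along the chain from an amine nitrogen and a carbonyl carbon.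

Going by the values given here, one measured step bears on this place, namely a step that the two limits leave unreadable from compound 2 to compound 3 in which carbamoyl gave way to 3-aminopropyl. That step has no readable size, and it shows two different groups here with both compounds sitting at the limit.

On that basis, the expected step is a number no higher from compound 3 to compound 4 (the limit leaves the size open) with no shift beyond the scatter expected in either direction. Compound 4 is estimated at 95% with a range from 85% to 100%. A limit rather than a number is also possible for compound 4.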

Compound 4, percent of the compound remaining: > 95%
Compound 4: only a limit was reported (the forecaster's own chance of this, stated with the estimate: 60%); the middle value sits exactly at the limit.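

In this assay compound 4 gives > 95%, which is a limit and not a number. No new step can be read among compound 2, compound 3 and compound 4, because all three stand at the same limit: the limit of > 95% in this assay, at which 3 of the 4 values shown sit.

The compounds shown leave open how far these three actually differ in stability, if they differ at all.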